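Amide-side ring exchange in a shared core: compound 1 to compound 3

The source may hold more compounds than are shown below. What is called first, only, known or untested is meant among the compounds shown, and "the series" means these compounds.

In a functional assay on the whole organism for inhibition, with Rattus norvegicus as the target, read by cytopathic effect and paw edema, at a dose of 100 mg/kg by the oral route (a higher number here means more inhibition at the dose given (going by the name of the read-out), a lower number less inhibition), compound 1 `Cc1ccc(NC(=O)c2c(O)c3cccnc3n(-c3ccccc3)c2=O)cc1` gives 2.2%, the lowest of the two numbers recorded, with compound 2 `O=C(Nc1ccc(Cl)cc1)c1c(O)c2cccnc2n(-c2ccccc2)c1=O` nearest at 2.5%. For the measured compounds named here, the only measured step, a number 0.3 percentage points higher from compound 1 to compound 2 (within the scatter), stays within the scatter, so these two numbers show no real separation. Compound 3 `O=C(Nc1nccs1)c1c(O)c2cccnc2n(-c2ccccc2)c1=O` is not yet measured in this assay. It differs from compound 1 by 1,3-thiazol-2-yl in place of 4-methylphenyl on an amide-type nitrogen. Going by the values given here, the one measured step also touches the group carried by the amide-type nitrogen, but it swapped a substituent on an aromatic carbon rather than exchanging the ring itself, and it was flat. Among the compounds with values here, no step in the set shows what a ring exchange of this kind does. On that basis the step of a number 0.8 percentage points higher from compound 1 to compound 3 (within the scatter) is expected to stay within the scatter. Compound 3 is estimated at 3%, within a range from -6% to 14%.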

Compound 3, a percentage reported as inhibition, in the whole organism at one dose (the size of the read-out at that dose, not a potency): 2.5%
Compound 3: middle estimate off by 0.5 percentage points, on the high side, and the stated range covers the measured number.
By their numbers in this assay, from the lowest: compounds 1, 2 and 3 (each within the scatter of the next).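

Exchanging the whole ring on the amide-type nitrogen, 4-methylphenyl for 1,3-thiazol-2-yl, gives a number 0.3 percentage points higher from compound 1 to compound 3 (within the scatter) in this assay and leaves no change at the digits printed from compound 2 to compound 3 (within the scatter) as the companion step from the 4-chlorophenyl compound. The flat result therefore extends from a substituent swap on the aromatic ring to a change of ring size and hetero atom content at this position, and the three compounds show no separation at this dose. No available evidence explains this flatness.

Open, going by these compounds, is whether a group of another kind on the amide-type nitrogen, such as a saturated ring carrying an amine, a phenyl ring bearing a carboxylic acid or a longer alkyl chain, would separate from these numbers. Also open, on these data alone, is whether any change elsewhere on the shared core would do so.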